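Flavanone ethers: fluoro to hydrogen on the benzyl group

The compounds below may be only part of what the source reports. "The series", "measured", "known", "first", "only" and "open" are said of these compounds alone.

Measured compounds:
compound 1 `O=C1CC(c2ccccc2OCc2ccc(F)cc2)Oc2ccccc21` — 42.1%
compound 2 `CC(C)COc1ccccc1C1CC(=O)c2ccccc2O1` — 33.5%
compound 3 `CCCCOc1ccccc1C1CC(=O)c2ccccc2O1` — 42.5%

In a functional assay on J774.A1 cells (Mus musculus) for inhibition, read by immunoassay, with a stated time of 12 h, tested at 30 uM (on this read-out higher numbers stand for more inhibition at the one concentration tested (going by the name of the read-out) and lower numbers for less inhibition), compound 1 gives 42.1%, the second highest of the three numbers, with compound 3 nearest at 42.5% and compound 2 furthest at 33.5%; all three lie within the scatter of one another, so no order among them can be read.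

Compound 4 `O=C1CC(c2ccccc2OCc2ccccc2)Oc2ccccc21` differs from compound 1 by hydrogen in place of fluoro on an aromatic carbon. Going by the values given here, no measured step changes this part of the structure. The three known steps all replace the whole group on the saturated chain carbon bound to the oxygen on the aromatic ring: a number 8.6 percentage points lower from compound 1 to compound 2 (within the scatter), a number 0.4 percentage points higher from compound 1 to compound 3 (within the scatter) and a number 9 percentage points higher from compound 2 to compound 3 (within the scatter). Even those larger exchanges left this assay essentially flat, and the loss of one fluorine is a smaller change than any of them. On that basis no step beyond the scatter is expected in this assay, in either direction.

Compound 4 is therefore expected to give about 42%, within 28% to 56%. The step this implies, a number 0.1 percentage points lower from compound 1 to compound 4 (within the scatter), is an expected step within the scatter.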

Compound 4, a percentage reported as inhibition, at one concentration (the size of the read-out at that concentration, not a potency): 91.5%
For compound 4 the middle estimate is 49.5 percentage points below the measured one; the measured number lies above the stated range.
By their numbers in this assay, from the lowest: compounds 2, 1 and 3 (each within the scatter of the next); then compound 4.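

In this assay, going by these compounds alone, the aromatic carbon para to a large group proves far from silent: hydrogen in place of fluoro, the loss of one fluorine, gives a number 49.4 percentage points higher from compound 1 to compound 4 (beyond the scatter) and so moves the number more than any exchange among the earlier compounds did. The benzyl ether of compound 4 also stands clear of the open chains, with a number 49 percentage points higher from compound 3 to compound 4 (beyond the scatter) and a number 58 percentage points higher from compound 2 to compound 4 (beyond the scatter) in the two exchanges for phenyl, yet compound 1 goes against any reading that an aromatic ring on this ether is enough, since its 4-fluorobenzyl group lay within the scatter of both chains. The data shown give no account of a step of this size.

From the compounds shown here alone, whether the step is specific to fluoro or would follow any group at this carbon stays open, and chloro, methyl or methoxy there would begin to separate those readings. Going by these compounds, each number also comes from one concentration, so how compound 4 and compound 1 would compare across a range of concentrations remains unknown.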